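This account rests on a few compounds, and the source may have more. Where it says the series, first, only, none or still open, it means among the compounds named here.

Compound 1 `COc1ccc2nc(C)cc(OCC(=O)Nc3cc(F)cc(F)c3)c2c1` and compound 2 `COc1ccc2nc(C)cc(OCC(=O)Nc3cc(OC)c(Cl)cc3OC)c2c1` share one core and differ in the group on the amide-type nitrogen. In a physicochemical assay for lipophilicity, read by HPLC, in phosphate buffer, measured as chromatographic lipophilicity, at pH 7.4 (a higher number here means a more lipophilic compound, a lower number a more polar compound), compound 1 gives 5.13, the lower of the two numbers, while compound 2 gives 5.8, a gap beyond the usual scatter. Compound 3 `COc1ccc2nc(C)cc(OCC(=O)Nc3noc(C)c3C)c2c1` carries 4,5-dimethyl-1,2-oxazol-3-yl in place of 3,5-difluorophenyl on an amide-type nitrogen and has not been measured in this assay. A downward step from compound 1 to compound 3 is expected, with a number 1.03 log units lower from compound 1 to compound 3 (beyond the scatter) larger than the scatter. Compound 3 is therefore estimated at 4.1, with a range from 3.5 to 4.7.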

Compound 3, distribution coefficient: 3.3
Compound 3: the middle estimate sits 0.80 log units above what was measured, and the stated range ends above it.
By their numbers in this assay, from the lowest: compound 3; then compound 1; then compound 2.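

In this assay, the group on the amide-type nitrogen proves able to shift the reading far more than the earlier pair showed: 4,5-dimethyl-1,2-oxazol-3-yl in place of 3,5-difluorophenyl gives a number 1.83 log units lower from compound 1 to compound 3 (beyond the scatter). Compounds 1 and 2 both carry a six-membered aromatic ring of carbon only at this place, so this is the one case shown of a five-membered aromatic ring with 2 hetero atoms there. No measurement shown accounts for the size of this step. On these data alone, whether ring size or the hetero atoms carry the step remains open. A pyridine ring at this place would help separate the two.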